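The source may report more compounds than this note shows. Statements on the series, on what has been measured and on what is new or still open speak of the compounds shown alone.

- Compound 1 `C=C[C@@](C)(/C=C/c1ccc(O)c(/C=C/C(N)=O)c1)CCC=C(C)C`: > 26000 nM
- Compound 2 `C=C[C@@](C)(/C=C/c1ccc(O)c(/C=C/c2ccc(Cl)cc2)c1)CCC=C(C)C`: > 26000 nM

Both entries come from a functional assay on Raji cells (Homo sapiens) for cytotoxicity, with a stated time of 72 h (a higher number here means that more compound is needed for the effect, a lower number that less compound is needed), and both are limits of the assay, not numbers. Compound 2 therefore stands only at its limit of > 26000 nM.

Compound 3 `C=C[C@@](C)(/C=C/c1ccc(O)c(/C=C/c2ccc(Cl)c(Cl)c2)c1)CCC=C(C)C` adds one change to compound 2: chloro in place of hydrogen on an aromatic carbon, or 4-chlorophenyl to 3,4-dichlorophenyl.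

Going by the values given here, the only measured step is a step that the two limits leave unreadable from compound 1 to compound 2. The record so far is the limit of > 26000 nM in this assay, at which 2 of the 2 values shown sit. This gives no measured size to build on, so no step beyond the scatter is expected, in either direction.

The expected step is a number no higher from compound 2 to compound 3 (the limit leaves the size open). For compound 3 the estimated value is 26000 nM, with an expected range of 10000 nM to 50000 nM.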

Compound 3, half-maximal effective concentration: > 26000 nM
Compound 3 ended at the assay's limit (the forecaster's own chance of this, stated with the estimate: 75%); the middle value sits exactly at the limit.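

The steps among compound 1, compound 2 and compound 3 cannot be read, as all three stand at the same limit: the limit of > 26000 nM in this assay, at which 3 of the 3 values shown sit.

The compounds shown leave open whether swapping these groups changes the concentration needed in this assay at all.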